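Replacing a para fluoro with trifluoromethyl on the aryl ring

The source may hold more compounds than are shown below. What is called first, only, known or untested is meant among the compounds shown, and "the series" means these compounds.

Measured so far:
Compound 1 `COC(=O)c1nc(C)n(-c2ccc(C(F)(F)F)cc2)n1`: 16600 nM
Compound 2 `COC(=O)c1nc(C2CCCC2)n(-c2ccc(F)cc2)n1`: 70500 nM

Of the compounds shown here, two sharing the same core have been tested in a functional assay on NCI-H226 cells (Homo sapiens) for inhibition, read by MTT assay, with a stated time of 72 h; a lower number here means a stronger inhibitor of growth, a higher number a weaker inhibitor of growth. Compound 1 gives 16600 nM in this assay. Compound 2 gives 70500 nM, the highest of the two numbers; its gap to compound 1 lies beyond the usual scatter, so compound 2 is the weaker growth inhibitor of the pair. The two differ in two places at once, so their gap cannot be assigned to either change alone.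

Compound 3 `COC(=O)c1nc(C2CCCC2)n(-c2ccc(C(F)(F)F)cc2)n1` has not yet been measured. It differs from compound 2 in one place: trifluoromethyl in place of fluoro on an aromatic carbon. With trifluoromethyl in place of fluoro, compound 3 carries the same aryl substituent as compound 1 while keeping the cyclopentyl group of compound 2. Because compound 1 gives 16600 nM, a lower number than compound 2, the trifluoromethyl-bearing compound 3 is expected to land somewhat below compound 2, though the step from compound 2 to compound 3 is estimated as a 2.0-fold lower number from compound 2 to compound 3 (0.30 log units; within the scatter), modest and not far beyond the scatter. For compound 3 the expected value in this assay is 35000 nM, within a range from 12000 nM to 100000 nM.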

Compound 3, concentration for 50% growth inhibition: 5710 nM
The estimate for compound 3 lay 6.1-fold (0.79 log units) above the measured number; measured number outside the range, below it.
By their numbers in this assay, from the lowest: compound 3; then compound 1; then compound 2.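

In this assay, trifluoromethyl in place of fluoro on the aromatic carbon gives a 12-fold lower number from compound 2 to compound 3 (1.09 log units; beyond the scatter), a large step that shows this place on the aryl ring strongly affects growth inhibition when cyclopentyl sits on the shared core. The other single change, cyclopentyl in place of methyl with trifluoromethyl kept on the aryl ring, gives a 2.9-fold lower number from compound 1 to compound 3 (0.46 log units; beyond the scatter), a modest step beyond the scatter, so the two changes that were tangled together in the earlier pair can now be read one at a time, and compound 3 is the strongest growth inhibitor of the three. Nothing shown here gives a reason for either step.

On these data alone, the trifluoromethyl step has been read only with cyclopentyl on the core, so its size with methyl in that place remains open, as does the effect of cyclopentyl with fluoro on the aryl ring held fixed. Also open, as far as these compounds go, is how other groups on this aromatic carbon, such as a nitrile, a methoxy group or an amine, would compare with trifluoromethyl.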